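Shortening the amide side chain: compound 3 to compound 4

A few compounds are considered here, and "the series" means these few. Any claim that something is new, unique, unknown or untested is made for them only; others in the source may bear on it.

Compound 3 `COc1ccc2nc(C)cc(OCC(=O)NCCCc3ccccc3)c2c1` reaches only a limit in an ADME assay on HepG2 cells (Homo sapiens) for cytotoxicity, read by trypan blue exclusion, with a stated time of 48 h, in the presence of a further agent that is not named here (a lower number here means that less compound is tolerated, a higher number that more compound is tolerated), > 137000 nM. Compound 1 `COc1ccc2nc(C)cc(OCC(=O)Nc3cccc(Br)c3)c2c1` likewise sits at a limit in this assay, > 125000 nM. Compound 2 `COc1ccc2nc(C)cc(OCC(=O)Nc3ccc(Cl)cc3)c2c1` gives a number in this assay, 89900 nM. The step of an at least 1.5-fold higher number from compound 2 to compound 3 (0.18 log units; that floor lies within the scatter) is read against (the limit of > 137000 nM in this assay, at which 1 of the 3 values shown sits), and the step that the two limits leave unreadable from compound 1 to compound 3 stays unreadable because both ends sit at the limit of > 125000 nM in this assay, at which 1 of the 3 values shown sits, and (the limit of > 137000 nM in this assay, at which 1 of the 3 values shown sits). Compound 4 `C#CCNC(=O)COc1cc(C)nc2ccc(OC)cc12` differs from compound 3 by ethynyl in place of phenethyl on a saturated chain carbon bound to an amide-type nitrogen. Among the measured compounds shown here, none of the measured steps alters the chain on the amide-type nitrogen in this way; they exchange the aryl groups. It is therefore expected that the step of an at least 1.0-fold lower number from compound 3 to compound 4 (0.02 log units; that floor lies within the scatter) in this assay is none beyond the scatter. Compound 4 is estimated at 130000 nM, between 60000 nM and 260000 nM.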

Compound 4, half-maximal cytotoxic concentration: > 176000 nM
Compound 4 ended at the assay's limit; the forecaster's own chance of this, stated with the estimate: 60%; at least 1.3-fold (0.13 log units) between middle value and limit.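

In this assay, compound 4, the only compound shown with a short propargyl chain and no aromatic ring on the amide-type nitrogen, also stays at a limit: the limit of > 176000 nM in this assay, at which 1 of the 4 values shown sits. The ring of compound 3 is therefore not needed for a result at the limit. Among the compounds shown here, the one readable step is an at least 1.9-fold higher number from compound 2 to compound 4 (0.29 log units; that floor lies within the scatter), while the steps to compound 4 from compound 1 and compound 3 cannot be read. As far as these compounds go, how far the true values of compounds 1, 3 and 4 lie beyond their limits remains open. So does whether an amine or a carboxylic acid on this chain would give a measurable number in this assay.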